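The source may report more compounds than this note shows. Statements on the series, on what has been measured and on what is new or still open speak of the compounds shown alone.

In a functional assay on HUVEC cells (Homo sapiens), read by scintillation counting and thymidine incorporation, with a stated time of 24 h (a higher number here means a weaker inhibitor, a lower number a stronger inhibitor), three related compounds have been measured. Compound 1 `CCC(C)n1ncn(-c2ccc(N3CCN(c4ccc(OC[C@@H]5COC(c6ccc(Cl)cc6Cl)O5)cc4)CC3)cc2)c1=O` gives 328 nM. Compound 2 `CCC(C)n1ncn(-c2ccc(N3CCN(c4ccc(OC[C@@H]5CO[C@@](Cn6cnc(C)n6)(c6ccc(Cl)cc6Cl)O5)cc4)CC3)cc2)c1=O` gives 272 nM. Compound 3 `CCc1nccn1C[C@@]1(c2ccc(Cl)cc2Cl)OC[C@@H](COc2ccc(N3CCN(c4ccc(-n5cnn(C(C)CC)c5=O)cc4)CC3)cc2)O1` gives 224 nM, which stands level with the other two, as all three values lie within the usual scatter of one another.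

Compound 4 `CCC(C)n1ncn(-c2ccc(N3CCN(c4ccc(OC[C@@H]5CO[C@@](Cn6cnnn6)(c6ccc(Cl)cc6Cl)O5)cc4)CC3)cc2)c1=O` has not yet been measured. It differs from compound 3 in one group, on a saturated chain carbon bound to a saturated ring carbon, where 1H-tetrazol-1-yl takes the place of 2-ethyl-1H-imidazol-1-yl: 1H-tetrazol-1-yl in place of 2-ethyl-1H-imidazol-1-yl on a saturated chain carbon bound to a saturated ring carbon.

Going by the values given here, the one measured step at this place, a 1.2-fold lower number from compound 2 to compound 3 (0.08 log units; within the scatter), swapped 3-methyl-1H-1,2,4-triazol-1-yl for 2-ethyl-1H-imidazol-1-yl and stayed within the scatter. Among the compounds with values here, no compound with 1H-tetrazol-1-yl has been measured, so this evidence is thin, and the range must stay wide. Even so, no step beyond the scatter is expected in this assay. The estimated change is a 1.3-fold higher number from compound 3 to compound 4 (0.10 log units; within the scatter). For compound 4 the expected value is 280 nM, with an estimated range of 110 nM to 700 nM.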

Compound 4, half-maximal inhibitory concentration: 73 nM
Beside the measured number, compound 4's estimate is 3.8-fold (0.58 log units) above it; the whole stated range lies above it.
By their numbers in this assay, from the lowest: compound 4; then compounds 3, 2 and 1 (each within the scatter of the next).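

In this assay, the group on a saturated chain carbon bound to a saturated ring carbon can clearly move the number: the earlier swap at this place stayed within the scatter, but 1H-tetrazol-1-yl in place of 2-ethyl-1H-imidazol-1-yl gives a 3.1-fold lower number from compound 3 to compound 4 (0.49 log units; beyond the scatter) and in place of 3-methyl-1H-1,2,4-triazol-1-yl gives a 3.7-fold lower number from compound 2 to compound 4 (0.57 log units; beyond the scatter) as well. So these five-membered aromatic rings are not interchangeable here, and the ring that gives the lowest number has fewer heavy atoms and more nitrogen atoms than 2-ethyl-1H-imidazol-1-yl. No supporting data explain this difference.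

The compounds shown leave open whether a small substituent on the tetrazole, as in 5-methyl-1H-tetrazol-1-yl, would keep this gain. They also do not show how a non-aromatic group at this place, such as a dimethylamino group or a carboxylic acid, would compare.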